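The source may report more compounds than this note shows. Statements on the series, on what has been measured and on what is new or still open speak of the compounds shown alone.

Measured compounds:
- compound 1 `CCCCOc1ccc2c(Cl)ccnc2c1`: in a functional assay on HCT-116 cells (Homo sapiens) for cytotoxicity, read by MTT assay, with a stated time of 48 h (a lower number here means a stronger inhibitor, a higher number a weaker inhibitor), compound 1 gives 2740 nM
- compound 2 `CCCCCCCCOc1ccc2c(Cl)ccnc2c1`: in this assay compound 2 gives 2820 nM
- compound 3 `CCOc1ccc2c(Cl)ccnc2c1`: in this assay compound 3 gives 3160 nM

Compound 3 carries the highest of the three numbers, but its nearest neighbour is compound 2 at a 1.1-fold higher number from compound 2 to compound 3 (0.05 log units; within the scatter) and its furthest is compound 1 at a 1.2-fold higher number from compound 1 to compound 3 (0.06 log units; within the scatter), so the three compounds cannot be ordered on these data.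

Compound 4 `Clc1ccnc2cc(OCCc3ccccc3)ccc12` is the next step from compound 3: phenyl in place of hydrogen on a saturated chain carbon, two bonds along the chain from an oxygen on an aromatic ring. Two of the measured steps alter the same place. Removing ethyl there gave a 1.2-fold higher number from compound 1 to compound 3 (0.06 log units; within the scatter), and removing hexyl there gave a 1.1-fold higher number from compound 2 to compound 3 (0.05 log units; within the scatter). The third step, lengthening the chain further out, gave a 1.0-fold higher number from compound 1 to compound 2 (0.01 log units; within the scatter). Every change so far at or beyond this chain carbon, whether the group shrank or grew, left the number where it was. A phenyl at the same place is a different kind of group, but nothing in the shown steps suggests it should behave differently; the expected step is therefore none beyond the scatter in this assay, in no particular direction, that is a 1.1-fold lower number from compound 3 to compound 4 (0.02 log units; within the scatter).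

Compound 4 is thus expected to give about 3000 nM in this assay, with a range from 1400 nM to 6500 nM.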

Compound 4, half-maximal inhibitory concentration: 2180 nM
Estimate against measurement, compound 4: 1.4-fold (0.14 log units) above, and the stated range covers the measured number.
By their numbers in this assay, from the lowest: compounds 4, 1, 2 and 3 (each within the scatter of the next).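

Among the compounds shown here, the phenyl puts a six-membered aromatic ring of carbon only at a place where the earlier steps had changed only saturated chains, and in this assay the steps stay within the scatter whether it is read against hydrogen (a 1.4-fold lower number from compound 3 to compound 4 (0.16 log units; within the scatter)), against hexyl (a 1.3-fold lower number from compound 2 to compound 4 (0.11 log units; within the scatter)) or against ethyl (a 1.3-fold lower number from compound 1 to compound 4 (0.10 log units; within the scatter)). On these four compounds, then, the saturated chain carbon two bonds along the chain from an oxygen on an aromatic ring has carried both a saturated chain and a ring without the number leaving the scatter, and none of the four can be ranked ahead of another. Nothing shown offers a measured reason for these numbers.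

Going by these compounds, whether an amine or a carboxylic acid at this chain carbon, or a fluorine or methoxy group on the new phenyl, would move the number remains open. On these data alone, all four compounds also share the same core and differ only in the chain on the oxygen, so it is equally open whether this picture would hold if an amine took the place of the chlorine on that core.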